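The source may hold more compounds than are shown below. What is called first, only, known or untested is meant among the compounds shown, and "the series" means these compounds.

Of the compounds shown here, three have been tested in a functional assay on HEK293 cells for agonist activity at G-protein coupled receptor 39 (Homo sapiens), read by scintillation proximity assay and inositol phosphate accumulation, with a stated time of 75 min, in the presence of a further agent that is not named here; a lower number here means that less compound is needed, a higher number that more compound is needed for the effect. Compound 2 `CCCCCCCCOC1CC(=O)Nc2c1c(C)nn2-c1ncnc2nc[nH]c12` gives 8 nM, compound 3 `Cc1nn(-c2ncnc3nc[nH]c23)c2c1C(OCc1ccc(C(C)C)cc1)CC(=O)N2` gives 5 nM, and compound 1 `C/C(=N\NC(=O)c1cc2ccccc2cc1O)c1ccc(N)cc1` gives 1100 nM. Compound 2 thus holds the second highest of the three numbers: the step of a 1.6-fold lower number from compound 2 to compound 3 (0.20 log units; within the scatter) lies within the scatter, while compound 1 sits far higher. Compound 4 `Cc1nn(-c2ncnc3nc[nH]c23)c2c1C(NC(=O)c1ccccc1)CC(=O)N2` differs from compound 2 in one place: benzamido in place of octyloxy on a saturated ring carbon. Among the measured compounds shown here, only one measured step touches that position, a 1.6-fold lower number from compound 2 to compound 3 (0.20 log units; within the scatter), and it keeps the oxygen and swaps just the chain's end, so it says little about replacing the whole octyloxy with benzamido. The expectation is therefore loosely held: compound 4 is estimated at 40 nM, between 8 nM and 300 nM, an expected step of a 5.0-fold higher number from compound 2 to compound 4 (0.70 log units; beyond the scatter).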

Compound 4, half-maximal effective concentration: 3 nM
Compound 4: the middle estimate sits 13-fold (1.12 log units) above what was measured; measured number below the stated range.
By their numbers in this assay, from the lowest: compounds 4, 3 and 2 (each within the scatter of the next, the first and the last beyond it); then compound 1.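

In this assay the earlier step kept the oxygen and changed only the chain's end, whereas here the whole octyloxy leaves and benzamido in its place gives a 2.7-fold lower number from compound 2 to compound 4 (0.43 log units; beyond the scatter) as a modest gain. This position therefore tolerates more than oxygen-linked chains: neither the oxygen link nor the octyl chain is needed for a low number. No measurement shown explains this gain. The compounds shown leave open whether the amide hydrogen or the benzene ring matters more, and how a simple amine or a carboxylic acid on this carbon would compare.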